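Taking the fluoro group off compound 2

This account rests on a few compounds, and the source may have more. Where it says the series, first, only, none or still open, it means among the compounds named here.

In a functional assay on HeLa cells (Homo sapiens) for antiproliferative activity, with a stated time of 5 days (a higher number here means a weaker inhibitor, a lower number a stronger inhibitor), compound 1 (`CC1OC2(C=CC(=O)C=C2)N(c2nc(-c3cccc4ccccc34)nn2-c2ccccc2)C1=O`) gives 110 nM while compound 2 (`O=C1C=CC2(C=C1)OCC(=O)N2c1nc(-c2ccc(F)c3ccccc23)nn1-c1ccccc1`) gives 200 nM as its value. Going by the values given here, these two values lie within the usual scatter of each other, so compound 2 stands level with the only other measured compound. Compound 3 (`O=C1C=CC2(C=C1)OCC(=O)N2c1nc(-c2cccc3ccccc23)nn1-c1ccccc1`) still awaits measurement. It differs from compound 2 in one place: hydrogen in place of fluoro on an aromatic carbon with hydrogen in place of fluoro on an aromatic carbon, which turns 4-fluoronaphthalen-1-yl into naphthalen-1-yl. Among the compounds with values here, no measured pair shows this change on its own, so no shift beyond the scatter is expected in this assay in either direction. The expected result is close to the values of compound 1 at 110 nM and compound 2 at 200 nM as measured. The estimated step of a 1.3-fold lower number from compound 2 to compound 3 (0.12 log units; within the scatter) is small. For compound 3 the estimate is 150 nM with an expected range from 60 nM to 370 nM still to be tested.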

Compound 3, half-maximal inhibitory concentration: 70 nM
For compound 3 the middle estimate is 2.1-fold (0.33 log units) above the measured one; the range from low to high includes it.
By their numbers in this assay, from the lowest: compounds 3, 1 and 2 (each within the scatter of the next, the first and the last beyond it).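

In this assay, going by these compounds alone, the step of a 2.9-fold lower number from compound 2 to compound 3 (0.46 log units; beyond the scatter) is a modest one beyond the scatter, and it gives the first reading of this position: with hydrogen in place of fluoro on this aromatic carbon, turning 4-fluoronaphthalen-1-yl into naphthalen-1-yl, the number falls, so the fluoro group is not needed for activity in these cells. The other new step, a 1.6-fold lower number from compound 1 to compound 3 (0.20 log units; within the scatter) with hydrogen in place of methyl on a saturated ring carbon, lies within the scatter, so this assay does not separate those two compounds. Nothing available explains the effect of removing the fluoro group.

The compounds shown leave open whether a chloro group, a methoxy group or an amine on the same aromatic carbon would read like hydrogen or like fluoro. They also leave open whether a longer chain in place of the methyl on the saturated ring carbon would shift the number beyond the scatter.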